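The compounds below may be only part of what the source reports. "The series", "measured", "known", "first", "only" and "open" are said of these compounds alone.

In a functional assay on B16-F10 cells (Mus musculus) for inhibition, read by colorimetric assay and MTT assay, with a stated time of 72 h (on this read-out lower numbers stand for stronger inhibition and higher numbers for weaker inhibition), compound 1, with the structure `COc1ccc(C(=O)NNC(=S)Nc2csc(-c3ccccc3)c2)cc1`, gives 33000 nM. Compound 2, `COc1ccc(C(=O)NNC(=S)Nc2csc(-c3ccc(C)cc3)c2)cc1`, differs from it by methyl in place of hydrogen on an aromatic carbon and in this assay compound 2 gives 9000 nM, a step described as a 3.7-fold lower number from compound 1 to compound 2 (0.56 log units; beyond the scatter). Compound 3, `Oc1ccc(-c2nnc(Nc3csc(-c4ccccc4)c3)s2)cc1`, belongs to a different core; the difference between the two cores is not broken down here. In this assay compound 3 gives 8000 nM, a number within the scatter of that of compound 2 and beyond the scatter from that of compound 1. Compound 4, `Cc1ccc(-c2cc(Nc3nnc(-c4ccc(O)cc4)s3)cs2)cc1`, is not yet measured and differs from compound 3 by methyl in place of hydrogen on an aromatic carbon, the same change that separates compound 1 from compound 2. Because the earlier step was a 3.7-fold lower number from compound 1 to compound 2 (0.56 log units; beyond the scatter), compound 4 is expected to show a step of a 2.9-fold lower number from compound 3 to compound 4 (0.46 log units; beyond the scatter). The estimate for compound 4 in this assay is 2800 nM, between 900 nM and 9000 nM.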

Compound 4, half-maximal inhibitory concentration: 6000 nM
For compound 4 the middle estimate is 2.1-fold (0.33 log units) below the measured one, and the stated range covers the measured number.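

In this assay, methyl in place of hydrogen on an aromatic carbon gives a 1.3-fold lower number from compound 3 to compound 4 (0.12 log units; within the scatter), so the change does not carry over to this core at the size it had on the core of compound 1. The two steps differ: the same change on two cores in this assay, a 3.7-fold lower number (0.56 log units; beyond the scatter) from compound 1 to compound 2 and a 1.3-fold lower number (0.12 log units; within the scatter) from compound 3 to compound 4, 2.8-fold (0.44 log units) apart, beyond the scatter of two such steps. This shows that the size of the step is not constant across these two cores, but it does not show why, and a single pair of cores cannot predict the step on any further core.

The compounds shown leave open whether an ethyl group, a chlorine atom or an amine in place of the methyl would give the same step on both cores. As far as these compounds go, it also remains open how a carboxylic acid in place of the hydroxyl of compound 3 would read.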